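The source may report more compounds than this note shows. Statements on the series, on what has been measured and on what is new or still open speak of the compounds shown alone.

This study concerns close relatives that share one core and differ only in the group on the amide-type nitrogen. Compound 1 `CCn1c(C(=O)NCC(=O)OC)ccc1C(CC)(CC)c1ccc(OCS(=O)(=O)c2ccccc2)c(C)c1` is the reference. In a functional assay on PC-3 cells (Homo sapiens) for antiproliferative activity, read by MTT assay, with a stated time of 24 h (on this read-out lower numbers stand for stronger inhibition and higher numbers for weaker inhibition), compound 1 gives > 50000 nM, which is a limit of the assay rather than a number. Compound 2 `CCn1c(C(=O)N[C@H](CO)C(C)C)ccc1C(CC)(CC)c1ccc(OCS(=O)(=O)c2ccccc2)c(C)c1` gives 7300 nM in this assay, and compound 3 `CCn1c(C(=O)N[C@H](CO)CCCO)ccc1C(CC)(CC)c1ccc(OCS(=O)(=O)c2ccccc2)c(C)c1` gives 6810 nM. The two measured moves away from compound 1 were both at least modest: an at least 6.8-fold lower number from compound 1 to compound 2 (0.83 log units; beyond the scatter) and an at least 7.3-fold lower number from compound 1 to compound 3 (0.86 log units; beyond the scatter), while between compound 2 and compound 3 the change, a 1.1-fold lower number from compound 2 to compound 3 (0.03 log units; within the scatter), stays within the scatter. Going by the values given here, compound 4 `CCn1c(C(=O)N[C@@H](C)C(=O)O)ccc1C(CC)(CC)c1ccc(OCS(=O)(=O)c2ccccc2)c(C)c1` carries a different change, (1-carboxyethyl in place of (methoxycarbonyl)methyl on an amide-type nitrogen), and no measured step shows a 1-carboxyethyl group here. Since compound 1 sits at the limit of > 50000 nM in this assay, at which 1 of the 3 values shown sits, any direction can only be guessed; the expected step is an at least 1.6-fold lower number from compound 1 to compound 4 (0.22 log units; that floor lies within the scatter), with much uncertainty. Compound 4 is thus estimated at 30000 nM, within a range from 8000 nM to 100000 nM, and a limit rather than a number is quite possible.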

Compound 4, half-maximal inhibitory concentration: 16800 nM
The estimate for compound 4 lay 1.8-fold (0.25 log units) above the measured number; the range from low to high includes it.
By their numbers in this assay, from the lowest: compounds 3 and 2 (each within the scatter of the next); then compound 4. At a limit, above all of these: compound 1.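

Rearranging the same atoms, from (methoxycarbonyl)methyl to 1-carboxyethyl on the amide-type nitrogen, gives an at least 2.9-fold lower number from compound 1 to compound 4 (0.47 log units; beyond the scatter), so in this assay the way these atoms are joined matters here, not only the size of the group. Compound 1 stands at a limit, so this step gives only a floor: the limit of > 50000 nM in this assay, at which 1 of the 4 values shown sits. Compound 4 still falls short of the two compounds with larger hydroxyl-bearing groups, with a 2.5-fold higher number from compound 3 to compound 4 (0.39 log units; beyond the scatter) and a 2.3-fold higher number from compound 2 to compound 4 (0.36 log units; beyond the scatter).

In compound 4 the carboxylic acid and the new defined stereocentre arrive together, so the compounds shown cannot tell which of them accounts for the step. On these data alone, a carboxymethyl group, the opposite stereocentre, a longer chain ending in a carboxylic acid, or an amine at this place all remain open.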